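This account rests on a few compounds, and the source may have more. Where it says the series, first, only, none or still open, it means among the compounds named here.

Measured in an in vitro ADME assay on microsomes from liver (Homo sapiens) for metabolic stability, tested at 1 uM; on this read-out higher numbers stand for fast clearance and lower numbers for slow clearance:
- compound 1 `CNC(=O)c1cc(N)c(Nc2ccc(C#N)cc2)cc1Oc1c(C)cc(CCC#N)cc1C`: 120 mL.min-1.g-1
- compound 2 `Cc1cc(/C=C/C#N)cc(C)c1Oc1cc(Nc2ccc(C#N)cc2)c(N)cc1[N+](=O)[O-]`: 150 mL.min-1.g-1
- compound 3 `Cc1cc(CCC#N)cc(C)c1Oc1cc(Nc2ccc(C#N)cc2)c(N)cc1CO`: 330 mL.min-1.g-1

Compound 2 lies within the scatter of compound 1 and clearly under compound 3. Compound 4 `COC(=O)c1cc(N)c(Nc2ccc(C#N)cc2)cc1Oc1c(C)cc(/C=C/C#N)cc1C` differs from compound 2 by a single change: methoxycarbonyl in place of nitro on an aromatic carbon. For the measured compounds named here, no measured step makes this exact exchange. Going by the values given here, the one measured step, a 2.8-fold higher number from compound 1 to compound 3 (0.44 log units; beyond the scatter), came with hydroxymethyl in place of methylcarbamoyl on an aromatic carbon and was modest. It involves neither nitro nor methoxycarbonyl, so it offers a size more than a direction. The expected step is a 1.3-fold higher number from compound 2 to compound 4 (0.12 log units; within the scatter), leaning upward and no larger than that modest one. Compound 4 is estimated at 200 mL.min-1.g-1, with an expected range of 90 mL.min-1.g-1 to 450 mL.min-1.g-1.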

Compound 4, intrinsic clearance in microsomes: 20 mL.min-1.g-1
Estimate against measurement, compound 4: 10-fold (1.00 log units) above; measured number below the stated range.
By their numbers in this assay, from the lowest: compound 4; then compounds 1 and 2 (each within the scatter of the next); then compound 3.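

In this assay, methoxycarbonyl in place of nitro on this aromatic carbon gives a 7.5-fold lower number from compound 2 to compound 4 (0.88 log units; beyond the scatter), even though the two groups have the same counts of hydrogen-bond donors and acceptors. For the compounds shown here, the only earlier step at this position, hydroxymethyl in place of methylcarbamoyl, went upward, so this is the first sign that a change here can also lower clearance. Nothing shown explains the size of this drop. From the compounds shown here alone, how a carboxylic acid or an ethoxycarbonyl group would read at this position on the core of compound 4 remains open.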